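Notes on the 2-chlorophenyl to 4-chlorophenyl swap

A few compounds are considered here, and "the series" means these few. Any claim that something is new, unique, unknown or untested is made for them only; others in the source may bear on it.

In a functional assay on HT-29 cells (Homo sapiens) for cytotoxicity, read by sulforhodamine B assay (a lower number here means a stronger inhibitor of growth, a higher number a weaker inhibitor of growth), compound 1 `CC1=CC[C@@H]([C@@](C)(O)CCCC(C)(C)NC(=S)N/N=C\c2ccc(C)cc2)CC1` gives 10400 nM and compound 2 `CC1=CC[C@@H]([C@@](C)(O)CCCC(C)(C)NC(=S)N/N=C\c2ccccc2Cl)CC1` gives 23700 nM. Compound 2 therefore holds the higher of the two numbers and is the weaker growth inhibitor of this pair. Compound 3 `CC1=CC[C@@H]([C@@](C)(O)CCCC(C)(C)NC(=S)N/N=C\c2ccc(Cl)cc2)CC1` is still unmeasured. Its difference from compound 2 is 4-chlorophenyl in place of 2-chlorophenyl on a carbon with a double bond to nitrogen: 4-chlorophenyl stands in place of 2-chlorophenyl on a carbon with a double bond to nitrogen, and the two compounds have the same atoms, joined differently.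

For the measured compounds named here, only one measured step bears on this change: a 2.3-fold higher number from compound 1 to compound 2 (0.36 log units; beyond the scatter), a modest step with 2-chlorophenyl in place of 4-methylphenyl. That step alters the group and its numbering together, so the data do not separate the two. Going by the values given here, with only two measured compounds, any trend remains tentative. A modest fall is nevertheless expected, resting on the 4-methylphenyl compound 1 at 10400 nM, and it should be no larger than the measured step. The expected change is a 1.8-fold lower number from compound 2 to compound 3 (0.26 log units; within the scatter). For compound 3 the estimated value is 13000 nM, with a range of 6500 nM to 26000 nM.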

Compound 3, concentration for 50% growth inhibition: 7350 nM
Compound 3: middle estimate off by 1.8-fold (0.25 log units), on the high side; low and high end bracket the measured number.
By their numbers in this assay, from the lowest: compounds 3 and 1 (each within the scatter of the next); then compound 2.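

In this assay, a 3.2-fold lower number from compound 2 to compound 3 (0.51 log units; beyond the scatter), and since the two compounds have the same atoms joined differently, this step isolates where the chloro sits on the phenyl ring, which the earlier step could not do because it changed the group and its numbering together. The group itself shows no such separation: with the 4-methylphenyl and 4-chlorophenyl groups compared, a 1.4-fold lower number from compound 1 to compound 3 (0.15 log units; within the scatter), so chloro in place of methyl on an aromatic carbon gives no readable change here. Among these three compounds, the clearly higher number belongs to the 2-chlorophenyl compound alone, and none of the three goes against that reading. Nothing on hand gives a reason for the difference between compound 2 and compound 3.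

For the compounds shown here, compound 2 is the only compound here with the 2-chlorophenyl group, so it remains open whether the higher number follows that numbering in general or applies to chloro alone. Also open, as far as these compounds go, is whether a nitrile or a methoxy group in place of the chloro of compound 3 would move the number beyond the scatter.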